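A few compounds are considered here, and "the series" means these few. Any claim that something is new, unique, unknown or untested is made for them only; others in the source may bear on it.

Working notes on the series built on the shared core of compound 1 `CC1=C(/C=C/C(=O)/C=C/c2ccccc2)C(C)(C)CCC1O`, which in a functional assay on LNCaP cells (Homo sapiens) for cytotoxicity, read by MTT assay, with a stated time of 72 h (on this read-out lower numbers stand for stronger inhibition and higher numbers for weaker inhibition), gives 5800 nM. Compound 2 `CC1=C(/C=C/C(=O)/C=C/c2ccc(F)cc2)C(C)(C)CCC1O` gives 3900 nM in this assay. Compound 3 `CC1=C(/C=C/C(=O)/C=C/c2cccc(C#N)c2)C(C)(C)CCC1O` gives 1800 nM, the lowest of the three numbers, the steps being a 2.2-fold lower number from compound 2 to compound 3 (0.34 log units; beyond the scatter) and a 3.2-fold lower number from compound 1 to compound 3 (0.51 log units; beyond the scatter). Compound 4 `COc1cccc(/C=C/C(=O)/C=C/C2=C(C)C(O)CCC2(C)C)c1` differs from compound 3 by methoxy in place of cyano on an aromatic carbon. Going by the values given here, no measured step exchanges one ring substituent for another; the bearing steps are the two ring substitutions a 1.5-fold lower number from compound 1 to compound 2 (0.17 log units; within the scatter) and a 3.2-fold lower number from compound 1 to compound 3 (0.51 log units; beyond the scatter), both toward lower numbers, only the cyano one beyond the scatter. Removal of the cyano is expected to undo part of a 3.2-fold lower number from compound 1 to compound 3 (0.51 log units; beyond the scatter). The expected step is a 1.9-fold higher number from compound 3 to compound 4 (0.29 log units; within the scatter). Compound 4 is therefore estimated at 3500 nM, range 1500 nM to 8000 nM.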

Compound 4, half-maximal inhibitory concentration: 4900 nM
Compound 4: middle estimate off by 1.4-fold (0.15 log units), on the low side; the measured number falls inside the stated range.
By their numbers in this assay, from the lowest: compound 3; then compounds 2, 4 and 1 (each within the scatter of the next).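

In this assay, going by these compounds alone, the first exchange of one ring substituent for another shows that this place on the ring separates cyano from methoxy: a 2.7-fold higher number from compound 3 to compound 4 (0.43 log units; beyond the scatter). The methoxy step from the unsubstituted compound is a 1.2-fold lower number from compound 1 to compound 4 (0.07 log units; within the scatter), and the exchange of 4-fluorophenyl for 3-methoxyphenyl is a 1.3-fold higher number from compound 2 to compound 4 (0.10 log units; within the scatter). Of the three ring substituents shown, only cyano stands beyond the scatter from hydrogen, with fluoro and methoxy going against any general gain from ring substitution.

No evidence at hand explains the gap between cyano and methoxy. From the compounds shown here alone, whether an amine or a carboxylic acid at this place would read like cyano or like methoxy remains open.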